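This account rests on a few compounds, and the source may have more. Where it says the series, first, only, none or still open, it means among the compounds named here.

In an assay on microsomes from liver for inhibition of sterol O-acyltransferase 1 (Rattus norvegicus) (on this read-out higher numbers stand for weaker inhibition and lower numbers for stronger inhibition), compound 1 `C[C@@]1(O)CC(=O)OC(CSc2nc(-c3ccccc3)c(-c3ccccc3)[nH]2)C1` gives 170 nM, while compound 2 `C[C@]1(O)CC(=O)OC(CSc2nc(-c3ccccc3)c(-c3ccccc3)[nH]2)C1` gives 140 nM. These two share every atom and bond and differ only in how one ring stereocentre is drawn; the step of a 1.2-fold lower number from compound 1 to compound 2 (0.08 log units; within the scatter) shows that this drawing makes no difference beyond the scatter. Compound 3 `COc1ccc(-c2nc(SCC3C[C@](C)(O)CC(=O)O3)[nH]c2-c2ccc(OC)cc2)cc1` gives 420 nM, the highest number of the three, so it is the weakest inhibitor here. Compound 4 `COc1ccc(-c2nc(SCC3C[C@@](C)(O)CC(=O)O3)[nH]c2-c2ccc(OC)cc2)cc1` relates to compound 3 in the same way: the two compounds have the same atoms and bonds; at least one stereo element is drawn with a configuration in one of them and without one in the other: 1 of 2 stereo elements differ; a stereocentre at a saturated ring carbon is drawn S in compound 3 and R in compound 4. Among the compounds with values here, the earlier pair, with the fact that one of compounds 1 and 2 is drawn with a defined configuration and the other without, at the place where they differ, is the only guide, and it suggests no real change. Compound 4 is therefore expected to differ by a 1.1-fold lower number from compound 3 to compound 4 (0.04 log units; within the scatter), giving an estimated 380 nM in this assay, with a likely range from 200 nM to 750 nM.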

Compound 4, half-maximal inhibitory concentration: 340 nM
Compound 4: middle estimate off by 1.1-fold (0.05 log units), on the high side; the measured number falls inside the stated range.
By their numbers in this assay, from the lowest: compounds 2, 1, 4 and 3 (each within the scatter of the next, the first and the last beyond it).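

In this assay, the step of a 1.2-fold lower number from compound 3 to compound 4 (0.09 log units; within the scatter) shows that redrawing this ring stereocentre from S to R again changes nothing beyond the scatter. The earlier pair showed this only for the core of compound 1, and it now holds for a second core, that of compound 3. Within these two pairs, the result at this stereocentre does not depend on which of the two cores carries it.

Still open, on these data alone, is whether an amine or a carboxylic acid in place of the hydroxyl at this stereocentre would move the number. Within the data shown here, the second stereocentre, which carries the sulfur-linked chain, also remains undecided, since no compound here has a configuration drawn there.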